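This account rests on a few compounds, and the source may have more. Where it says the series, first, only, none or still open, it means among the compounds named here.

Compound 1 `Cc1cc(-c2ccc(Cl)cc2)c(/C=C/[C@@H]2C[C@@H](O)CC(=O)O2)c(C)n1`: in an assay for inhibition of 3-hydroxy-3-methylglutaryl-coenzyme A reductase (Rattus norvegicus) (on this read-out lower numbers stand for stronger inhibition and higher numbers for weaker inhibition), compound 1 gives 94 nM.
Compound 2 `Cc1cc(-c2ccc(F)cc2)c(/C=C/[C@@H]2C[C@@H](O)CC(=O)O2)c(C(C)C)n1`: in this assay compound 2 gives 9 nM.
Compound 3 `CC(C)c1nc(C2CCCCC2)cc(-c2ccc(F)cc2)c1/C=C/[C@@H]1C[C@@H](O)CC(=O)O1`: in this assay compound 3 gives 4 nM.

Compound 3 stands lowest of the three numbers in this assay; compound 2 comes nearest to it, and compound 1 lies furthest away. Within the data shown here, the one measured step that bears on the place in question, a 2.3-fold lower number from compound 2 to compound 3 (0.35 log units; beyond the scatter), shows that swapping methyl for a ring there lowered the number. Compound 4 `Cc1ccc(C)c(-c2cc(-c3ccc(F)cc3)c(/C=C/[C@@H]3C[C@@H](O)CC(=O)O3)c(C(C)C)n2)c1` differs from compound 3 by 2,5-dimethylphenyl in place of cyclohexyl on an aromatic carbon. Among the measured compounds shown here, no measured step exchanges one ring for another at this place, so the expectation for compound 4 is a step of about a 1.3-fold higher number from compound 3 to compound 4 (0.10 log units; within the scatter) in this assay, not beyond the scatter. Compound 4 is therefore estimated at 5 nM in this assay, within 2 nM to 15 nM.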

Compound 4, half-maximal inhibitory concentration: 5 nM
Compound 4: middle estimate and measured number agree at the digits printed; the measured number falls inside the stated range.
By their numbers in this assay, from the lowest: compounds 3, 4 and 2 (each within the scatter of the next, the first and the last beyond it); then compound 1.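

At this place, next to the ring nitrogen, the aromatic 2,5-dimethylphenyl and the non-aromatic cyclohexyl cannot be told apart in this assay, since a 1.3-fold higher number from compound 3 to compound 4 (0.10 log units; within the scatter) stays within the scatter. Against methyl, a 1.8-fold lower number from compound 2 to compound 4 (0.26 log units; within the scatter) also stays within the scatter, whereas a 2.3-fold lower number from compound 2 to compound 3 (0.35 log units; beyond the scatter) went beyond it, so not every six-membered ring here separates clearly from methyl. Nothing available offers a reason for these results. The compounds shown leave open how an amine, a carboxylic acid or a longer chain at this place would read in this assay.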